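The source may report more compounds than this note shows. Statements on the series, on what has been measured and on what is new or still open speak of the compounds shown alone.

Compound 2 `Cc1cc(O)c2c(c1Cl)C(=O)C=CC2=O` gives 15700 nM in a functional assay on MCF7 cells (Homo sapiens) for cytotoxicity, read by XTT assay, with a stated time of 24 h (on this read-out higher numbers stand for weaker inhibition and lower numbers for stronger inhibition), the lowest of the three numbers recorded there. Compound 1 `CCOc1cc(C)c(Cl)c2c1C(=O)C=CC2=O` gives 40000 nM, and compound 3 `CC(=O)Oc1cc(OC(C)=O)c2c(OC(C)=O)c(C)cc(Cl)c2c1OC(C)=O` gives 57500 nM. The one single-point step among these, a 2.5-fold lower number from compound 1 to compound 2 (0.41 log units; beyond the scatter), is a modest change, hydrogen in place of ethyl on an oxygen on an aromatic ring.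

Compound 4 `Cc1cc(O)c2c(c1Br)C(=O)C=CC2=O` differs from compound 2 by bromo in place of chloro on an aromatic carbon. Among the compounds with values here, no measured step concerns an exchange of one halogen for another on the shared core; the only step available, from compound 1 to compound 2, touches a different place and a different kind of group, so it gives no direct guide. With nothing in the data pointing one way or the other, the expectation for compound 4 in this assay is a step no larger than the usual scatter, a 1.1-fold lower number from compound 2 to compound 4 (0.05 log units; within the scatter), in either direction. The estimated value for compound 4 is therefore 14000 nM, with a range from 6000 nM to 32000 nM.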

Compound 4, half-maximal inhibitory concentration: 15500 nM
Beside the measured number, compound 4's estimate is 1.1-fold (0.04 log units) below it; the measured number falls inside the stated range.
By their numbers in this assay, from the lowest: compounds 4 and 2 (each within the scatter of the next); then compounds 1 and 3 (each within the scatter of the next).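

In this assay, bromo in place of chloro on this aromatic carbon, para to a hydroxy group and ortho to a methyl group, gives a 1.0-fold lower number from compound 2 to compound 4 (0.01 log units; within the scatter) and so leaves the two halogens indistinguishable at this position. The earlier single-point step concerned the group on an oxygen, whereas this one shows that, on the shared core, the number does not separate the larger halogen from the smaller one at this carbon. No measurement in hand bears on why the exchange leaves the number where it stands.

The compounds shown carry only chloro or bromo on this carbon, so the effect of an amine, a nitrile or a plain hydrogen there remains open. Also open, going by these compounds, is whether ethyl on the oxygen of compound 4 would give the same step seen with chloro on the core.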